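This account rests on a few compounds, and the source may have more. Where it says the series, first, only, none or still open, it means among the compounds named here.

Measured compounds in this series:
- compound 1, `COC(=O)/C=C/c1cccc(N(Cc2ccc(/C=C/c3c(F)cccc3F)cc2)C(=O)C(C)C)c1`; in an assay on isolated protein with Bile acid receptor (Homo sapiens) as the target (a higher number here means that more compound is needed for the effect, a lower number that less compound is needed), compound 1 gives 108 nM
- compound 2, `COC(=O)/C=C/c1cccc(N(Cc2ccc(/C=C/c3ccccc3F)cc2)C(=O)C2CCCCC2)c1`; in this assay compound 2 gives 64 nM
- compound 3, `COC(=O)/C=C/c1cccc(N(Cc2ccc(/C=C/c3ccc(F)cc3)cc2)C(=O)NC(C)C)c1`; in this assay compound 3 gives 348 nM

Compound 1 stands second highest of the three numbers. Its nearest neighbour is compound 2, whose number is lower by an amount that lies within the usual scatter, so the two cannot be ordered. Compound 3 sits furthest away with a higher number, and that gap lies beyond the scatter. Within the data shown here, compounds 2 and 3 each differ from compound 1 in more than one place, so no single step between the measured compounds can be read off; only the bare values are available.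

The compound not yet measured is compound 4, `COC(=O)/C=C/c1cccc(N(Cc2ccc(/C=C/c3ccccn3)cc2)C(=O)C(C)C)c1`. Relative to compound 1 the change is pyridin-2-yl in place of 2,6-difluorophenyl on a double-bonded chain carbon bound to a double-bonded chain carbon. Among the measured compounds shown here, nothing among the measured compounds isolates this change: the fluorine pattern on the outer ring and the group on the amide nitrogen vary together in compounds 2 and 3. The expected step in this assay is therefore a small one, towards a somewhat higher number, quite possibly still within the scatter. The estimated step is a 1.9-fold higher number from compound 1 to compound 4 (0.27 log units; within the scatter). Compound 4 is expected to give about 200 nM, with a range from 70 nM to 600 nM.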

Compound 4, half-maximal effective concentration: 310 nM
Estimate against measurement, compound 4: 1.6-fold (0.19 log units) below; measured number inside the range.
By their numbers in this assay, from the lowest: compounds 2 and 1 (each within the scatter of the next); then compounds 4 and 3 (each within the scatter of the next).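

In this assay, among these compounds, pyridin-2-yl in place of 2,6-difluorophenyl on a double-bonded chain carbon bound to a double-bonded chain carbon gives a 2.9-fold higher number from compound 1 to compound 4 (0.46 log units; beyond the scatter) and is the first single-place comparison, showing that the outer ring at this place affects the number with the rest of the structure held constant. The swap removes the fluorines and introduces a ring nitrogen counted as a hydrogen-bond acceptor, so these two changes travel together and their contributions cannot be separated here. Nothing available on these compounds bears on the reason for the step.

Steps involving compound 2 or compound 3 cannot be read, as each differs from both compound 1 and compound 4 in more than one place. Still open, as far as these compounds go, is whether an unsubstituted phenyl or a pyridin-3-yl at this place, with the rest of compound 1 kept, would fall nearer compound 1 or compound 4, and whether the step would keep its size with a carboxylic acid in place of the methyl ester.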